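Pentyl chain in place of phenylethyl on the ether oxygen

The compounds below may be only part of what the source reports. "The series", "measured", "known", "first", "only" and "open" are said of these compounds alone.

Compound 1 `COc1ccc2c(c1)[n+]([O-])nc(NCOC(C)c1ccccc1)[n+]2[O-]` gives only a limit in a functional assay on PC-3 cells (Homo sapiens) for cytotoxicity, read by MTT assay, with a stated time of 72 h (a lower number here means a stronger inhibitor, a higher number a weaker inhibitor), reported as > 100000 nM (the limit of > 100000 nM in this assay, at which 1 of the 3 values shown sits). The analogues on the unsubstituted core are measurable: compound 2 `COCNc1n[n+]([O-])c2ccccc2[n+]1[O-]` gives 4270 nM, and compound 3 `[O-][n+]1nc(NCOCc2ccc(Cl)cc2)[n+]([O-])c2ccccc21` gives 5100 nM. Going by the values given here, the one measured step, a 1.2-fold higher number from compound 2 to compound 3 (0.08 log units; within the scatter), shows that enlarging the ether substituent from hydrogen to 4-chlorophenyl leaves the number unchanged. Compound 4 `CCCCCOCNc1n[n+]([O-])c2cc(OC)ccc2[n+]1[O-]` differs from compound 1 by pentyl in place of 1-phenylethyl on an oxygen on a saturated carbon. Among the compounds with values here, no measured step covers this exchange, and compound 1 stands only at a limit, so the guidance is indirect. The estimate for compound 4 is 20000 nM, with a range from 4000 nM to 100000 nM. That amounts to an expected step of an at least 5.0-fold lower number from compound 1 to compound 4 (0.69 log units; beyond the scatter), toward a measurable number.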

Compound 4, half-maximal inhibitory concentration: 30900 nM
Compound 4: the middle estimate sits 1.5-fold (0.19 log units) below what was measured; low and high end bracket the measured number.
By their numbers in this assay, from the lowest: compounds 2 and 3 (each within the scatter of the next); then compound 4. At a limit, above all of these: compound 1.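

Pentyl in place of 1-phenylethyl on an oxygen on a saturated carbon gives an at least 3.2-fold lower number from compound 1 to compound 4 (0.51 log units; beyond the scatter) in this assay, a change beyond the scatter, whereas a 1.2-fold higher number from compound 2 to compound 3 (0.08 log units; within the scatter) on the unsubstituted core stayed within it. With pentyl, which has no ring, the core of compound 1 reaches a measurable number. Compound 1 stands only at a limit: the limit of > 100000 nM in this assay, at which 1 of the 4 values shown sits.

On these data alone, it remains open whether a longer chain or a terminal amine in place of pentyl would move the number further. No pair shown isolates the methoxy group on the core.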